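A few compounds are considered here, and "the series" means these few. Any claim that something is new, unique, unknown or untested is made for them only; others in the source may bear on it.

Compound 2 `CN1CCC[C@@H](Cn2c(CN(C)[C@@H]3CCCc4cccnc43)nc3ccccc32)C1` holds the lowest of the three numbers in an ADME assay on HOS cells (Homo sapiens) for cytotoxicity; on this read-out lower numbers stand for higher toxicity in this test and higher numbers for lower toxicity in this test: compound 2 gives 2800 nM, whereas compound 1 `CN1CCC(Cn2c(CN(C)C3CCCc4cccnc43)nc3ccccc32)C1` gives 15000 nM and compound 3 `CN(Cc1nc2ccccc2n1CC1CNC1)C1CCCc2cccnc21` gives 15000 nM. Within the data shown here, the only one-place step measured so far, no change at the digits printed from compound 1 to compound 3 (within the scatter), concerns a different part of the molecule. Compound 4 `CN1CCC[C@@H](Cn2c(CN(C)[C@H]3CCCc4cccnc43)nc3ccccc32)C1` differs from compound 2 as follows: the two compounds have the same atoms and bonds and differ only in configuration as drawn: 1 of 2 stereo elements differ; a stereocentre at a saturated ring carbon is drawn R in compound 2 and S in compound 4. Among the measured compounds shown here, no measured step addresses a change of configuration of this kind. Compound 1 is drawn without configuration and gives 15000 nM, while compound 2 gives 2800 nM, so the other configuration at that ring carbon may well return a higher number. Compound 4 is therefore expected near 8000 nM, range 2500 nM to 25000 nM, an estimated step of a 2.9-fold higher number from compound 2 to compound 4 (0.46 log units; beyond the scatter).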

Compound 4, half-maximal cytotoxic concentration: 3500 nM
The estimate for compound 4 lay 2.3-fold (0.36 log units) above the measured number; measured number inside the range.
By their numbers in this assay, from the lowest: compounds 2 and 4 (each within the scatter of the next); then compounds 1 and 3 (each within the scatter of the next).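

Changing the saturated ring carbon from R to S gives a 1.3-fold higher number from compound 2 to compound 4 (0.10 log units; within the scatter) in this assay. Among these compounds, at this position, therefore, the configuration gives no readable separation, a point that the earlier compounds, with no pair differing only in configuration, could not show. This reading holds only with the other stereocentre drawn alike in compound 2 and compound 4.

The compounds shown leave open whether changing that other stereocentre would separate the numbers. They also leave open how a carboxylic acid on the shared core would read in this assay.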